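The source may hold more compounds than are shown below. What is called first, only, known or untested is meant among the compounds shown, and "the series" means these compounds.

Compounds measured so far:
- compound 1 `Cc1cccc(/C=N/Nc2ncc3c(n2)n(C2CCCC2)c(=O)c(=O)n3C)c1`: > 100000 nM
- compound 2 `Cn1c(=O)c(=O)n(C2CCCC2)c2nc(N/N=C/c3ccc(O)c(F)c3)ncc21`: 59300 nM

All data come from a functional assay on HCT-116 cells (Homo sapiens) for antiproliferative activity, read by MTT assay; a lower number here means a stronger inhibitor, a higher number a weaker inhibitor. Compound 1 stands at > 100000 nM, which is a limit of the assay and not a number. Within the data shown here, compound 2 gives the only actual number so far, 59300 nM.

The next analogue is compound 3 `COc1cccc(/C=N/Nc2ncc3c(n2)n(C2CCCC2)c(=O)c(=O)n3C)c1`, with the change 3-methoxyphenyl in place of 3-fluoro-4-hydroxyphenyl on a carbon with a double bond to nitrogen.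

Among the measured compounds shown here, one measured step bears on this, an at least 1.6-fold lower number from compound 1 to compound 2 (0.22 log units; that floor lies within the scatter). That step is only a floor, so its true size is open. Compound 3 gives up the same 3-fluoro-4-hydroxyphenyl that separates compound 2 from compound 1, so the number in this assay is expected to move upward. The expected step is a 1.5-fold higher number from compound 2 to compound 3 (0.18 log units; within the scatter), a small one that may not clear the scatter. For compound 3 the estimated value is 90000 nM, with an expected range of 40000 nM to 160000 nM.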

Compound 3, half-maximal inhibitory concentration: 45800 nM
The estimate for compound 3 lay 2.0-fold (0.29 log units) above the measured number; measured number inside the range.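

In this assay, 3-methoxyphenyl, with 0 hydrogen-bond donors, cannot be told apart from 3-fluoro-4-hydroxyphenyl on the carbon with a double bond to nitrogen, as the step shows: a 1.3-fold lower number from compound 2 to compound 3 (0.11 log units; within the scatter); the hydrogen-bond donor of compound 2 is therefore not required to hold this level of activity. Methoxy in place of methyl on an aromatic carbon gives an at least 2.1-fold lower number from compound 1 to compound 3 (0.33 log units; beyond the scatter), the first step in the series to clear the scatter, and it stands only as a floor. Compound 1 is a limit and not a number: the limit of > 100000 nM in this assay, at which 1 of the 3 values shown sits.

As far as these compounds go, the true size of that step remains open. Also open, from the compounds shown here alone, is how this assay would respond to an amine or a carboxylic acid on the aromatic ring, or to a longer chain in place of the methoxy.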